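Removing one methoxy group from a trimethoxyphenyl pyrazole chalcone

A few compounds are considered here, and "the series" means these few. Any claim that something is new, unique, unknown or untested is made for them only; others in the source may bear on it.

The measured compounds and their values:
Compound 1, `COc1cc(-c2cc(/C=C/C(=O)c3ccc(N)cc3)[nH]n2)cc(OC)c1OC`, gives 76% in a functional assay on U-251 cells (Homo sapiens) for cytotoxicity, read by sulforhodamine B assay, with a stated time of 48 h, tested at 1 uM; a lower number here means a stronger effect, a higher number a weaker effect of the compound at the concentration tested.
Compound 2, `COc1ccc(C(=O)/C=C/c2cc(-c3cc(OC)c(OC)c(OC)c3)n[nH]2)cc1OC`, gives 65% in this assay.
Compound 3, `COc1ccc(C(=O)/C=C/c2cc(-c3cc(OC)c(OC)c(OC)c3)n[nH]2)cc1`, gives 81% in this assay.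

Compound 4, `COc1ccc(-c2cc(/C=C/C(=O)c3ccc(N)cc3)[nH]n2)cc1OC`, has not yet been measured in this assay. It differs from compound 1 by hydrogen in place of methoxy on an aromatic carbon. The same kind of change is already on record between two measured compounds: compound 3 differs from compound 2 by hydrogen in place of methoxy on an aromatic carbon, and in this assay that step was a number 16 percentage points higher from compound 2 to compound 3 (beyond the scatter). The two cores are not identical, however: compound 1 differs from compound 2 by 4-aminophenyl in place of 3,4-dimethoxyphenyl on a carbonyl carbon. The surroundings of the change also differ slightly, in that the carbon in compound 1 is additionally meta to a methoxy group, so the change is the same kind of change rather than the same one.

Taking the step seen from compound 2 to compound 3 as the nearest guide, the step expected from compound 1 to compound 4 in this assay is estimated as a number 10 percentage points higher from compound 1 to compound 4 (within the scatter), pointing in the same direction as a number 16 percentage points higher from compound 2 to compound 3 (beyond the scatter). On that basis compound 4 is expected to give about 86% in this assay, likely within 70% to 98%.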

Compound 4, a percentage reported as activity, at one concentration (the size of the read-out at that concentration, not a potency): 88%
For compound 4 the middle estimate is 2 percentage points below the measured one; low and high end bracket the measured number.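

In this assay, removing the methoxy group from compound 1 gave a number 12 percentage points higher from compound 1 to compound 4 (beyond the scatter), so the change moved the read-out in the same direction on this core as it had on the core of compound 2. The two steps agree in direction, and their sizes cannot be told apart: the same change on two cores in this assay, a number 16 percentage points higher (beyond the scatter) from compound 2 to compound 3 and a number 12 percentage points higher (beyond the scatter) from compound 1 to compound 4, 4 percentage points apart, within the scatter of two such steps. This suggests that, in these two cases, the loss of a methoxy group carries over from one core to the other, but two cases do not show that it would hold on any further core, and they do not explain the rise, as the methoxy group lost stands in different surroundings in each case.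

The compounds shown leave open what a hydroxyl group, a halogen or a longer chain such as ethoxy would do on that aromatic carbon. A read-out at a single concentration also shows only the stronger or weaker effect of these compounds at that concentration and leaves open how they would compare at any other.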